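A few compounds are considered here, and "the series" means these few. Any claim that something is new, unique, unknown or untested is made for them only; others in the source may bear on it.

Working notes on the series. For the measured compounds named here, compound 2 `O=C(O)c1csc(-n2nc(C3=CCCCC3)c3ccccc32)n1` is the reference point here: in an assay on isolated protein for antagonist activity at prostaglandin E2 receptor EP1 subtype (Homo sapiens), read by reporter gene assay (on this read-out higher numbers stand for weaker inhibition and lower numbers for stronger inhibition), compound 2 gives 4 nM, the lowest of the two numbers so far. Going by the values given here, its only measured neighbour is compound 1 `O=C(O)c1csc(-n2nc(C3=CCCC3)c3ccccc32)n1`, which in this assay gives 80 nM; the one recorded step, a 20-fold lower number from compound 1 to compound 2 (1.30 log units; beyond the scatter), came from replacing cyclopent-1-en-1-yl with cyclohex-1-en-1-yl on an aromatic carbon.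

Compound 3 `O=C(O)c1csc(-n2nc(-c3ccsc3)c3ccccc32)n1` is not yet measured. It differs from compound 2 in one place: thiophen-3-yl in place of cyclohex-1-en-1-yl on an aromatic carbon. Among the compounds with values here, the single measured step bears on it only indirectly, since it altered the size of a non-aromatic carbocycle, whereas here a five-membered aromatic ring with one hetero atom takes the place of the six-membered ring. Given that the series shows a large swing with ring size, and that compound 2 holds the best value, some movement back toward compound 1 is expected rather than a further gain. The expected step is a 5.0-fold higher number from compound 2 to compound 3 (0.70 log units; beyond the scatter). For compound 3 the estimate in this assay is 20 nM, with a range from 5 nM to 80 nM.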

Compound 3, half-maximal inhibitory concentration: 30 nM
Estimate against measurement, compound 3: 1.5-fold (0.18 log units) below, within the range that was stated.
By their numbers in this assay, from the lowest: compound 2; then compound 3; then compound 1.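

In this assay, this position on the aromatic carbon is not limited to a non-aromatic carbocycle: thiophen-3-yl keeps measurable inhibition, yet replacing cyclohex-1-en-1-yl with it gives a 7.5-fold higher number from compound 2 to compound 3 (0.88 log units; beyond the scatter). Ring size alone does not set the number, as the five-membered thiophen-3-yl and the five-membered cyclopent-1-en-1-yl are separated by a 2.7-fold lower number from compound 1 to compound 3 (0.43 log units; beyond the scatter), so the kind of ring matters at this position as well as its size; among these three compounds, the six-membered ring of compound 2 still gives the lowest number. No data on hand explain either difference.

The compounds shown leave open whether phenyl, an aromatic ring of six carbons, would reach the number of compound 2, which would separate the contribution of ring size from that of aromaticity among the groups at this position. Also open, on these data alone, are how thiophen-2-yl, with the sulfur placed differently relative to the point of attachment, and cyclohexyl, which lacks the double bond of cyclohex-1-en-1-yl, would compare with compound 3 and compound 2.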